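Extending a Methoxy to an Ethoxy: Expectation for Compound 4

The source may report more compounds than this note shows. Statements on the series, on what has been measured and on what is new or still open speak of the compounds shown alone.

Compound 1 `COc1ccc2c(=O)c(/C=C/C(=O)NCc3cccc(F)c3)coc2c1` gives 26900 nM in a functional assay on A549 cells (Homo sapiens) for inhibition, read by MTT assay, with a stated time of 48 h; a higher number here means a weaker inhibitor, a lower number a stronger inhibitor.
Compound 2 `COc1ccc(NC(=O)/C=C/c2coc3cc(OC)ccc3c2=O)cc1` gives 23000 nM in this assay.
Compound 3 `COc1ccc(NC(=O)/C=C/c2coc3cc(O)ccc3c2=O)cc1` gives 12800 nM in this assay.

Among these three numbers compound 2 holds the second highest. The step of a 1.2-fold lower number from compound 1 to compound 2 (0.07 log units; within the scatter) separates it from its nearer neighbour, and the step of a 1.8-fold lower number from compound 2 to compound 3 (0.25 log units; within the scatter) from its further one; both lie within the scatter, so the three measured compounds cannot be ranked against each other.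

Compound 4 `CCOc1ccc(NC(=O)/C=C/c2coc3cc(OC)ccc3c2=O)cc1` has not yet been measured. It differs from compound 2 by methyl in place of hydrogen on a saturated chain carbon bound to an oxygen on an aromatic ring. Neither measured step is this exact change: one swaps a whole substituent on the amide-type nitrogen, the other removes a methyl from an oxygen on an aromatic ring. Both, however, were small, and nothing in the measured set suggests that a one-carbon extension should move the number beyond the scatter.

Compound 4 is therefore expected to give 23000 nM in this assay, with a range from 10000 nM to 50000 nM. The expected step is no change at the digits printed from compound 2 to compound 4 (within the scatter).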

Compound 4, half-maximal inhibitory concentration: > 100000 nM
Compound 4: no number, only a limit; the forecaster's own chance of this, stated with the estimate: 10%; at least 4.3-fold (0.63 log units) between middle value and limit.
By their numbers in this assay, from the lowest: compounds 3, 2 and 1 (each within the scatter of the next, the first and the last beyond it). At a limit, above all of these: compound 4.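

In this assay compound 4 has no number, only a limit of the assay: the limit of > 100000 nM in this assay, at which 1 of the 4 values shown sits. This position on the amide-type nitrogen's aryl group therefore responds to a small change: methyl in place of hydrogen on a saturated chain carbon bound to an oxygen on an aromatic ring gives an at least 4.3-fold higher number from compound 2 to compound 4 (0.63 log units; beyond the scatter), whereas every earlier step stayed within the scatter. Read from 3-fluorobenzyl, the 4-ethoxyphenyl group also gives a step beyond the scatter, an at least 3.7-fold higher number from compound 1 to compound 4 (0.57 log units; beyond the scatter), which 4-methoxyphenyl in the same place did not.

From the compounds shown here alone, how far the true value of compound 4 lies past its limit remains open, so the full size of both steps is unknown. Also open, going by these compounds, is whether a longer chain, such as propoxy, or an amine in this place would follow 4-methoxyphenyl or 4-ethoxyphenyl.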